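A Bromo Substituent on the Core of Compound 1

The compounds below may be only part of what the source reports. "The series", "measured", "known", "first", "only" and "open" are said of these compounds alone.

compound 1 `O=C(NS(=O)(=O)c1cccc([N+](=O)[O-])c1)n1ccc2cccnc21`: 18.9%
compound 2 `Cc1ccc(S(=O)(=O)NC(=O)n2ccc3cccnc32)cc1`: 33.4%
compound 3 `O=C(NS(=O)(=O)c1ccc2ccccc2c1)n1ccc2cccnc21`: 16.2%

Of the compounds shown here, three sharing one core have been tested in a functional assay on HT-29 cells (Homo sapiens) for antiproliferative activity, read by MTT assay, with a stated time of 24 h, tested at 10 uM; on this read-out lower numbers stand for less inhibition and higher numbers for more inhibition at the one concentration tested (going by the name of the read-out). In this assay compound 1 gives 18.9%, the second highest of the three numbers. Compound 3 gives 16.2%, a number that lies within the scatter of compound 1, so the two cannot be told apart. Compound 2 gives 33.4%, a number that lies beyond the scatter above compound 1.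

The unmeasured compound 4 `O=C(NS(=O)(=O)c1cccc([N+](=O)[O-])c1)n1ccc2cc(Br)cnc21` is derived from compound 1 by a single change: bromo in place of hydrogen on an aromatic carbon. Among the measured compounds shown here, no pair among the measured compounds differs in this one place, so the data give no direct measure of what a bromo substituent on the core does in this assay. In the absence of such a step, compound 4 is expected to stay close to compound 1, and the step of a number 3.1 percentage points higher from compound 1 to compound 4 (within the scatter) is estimated to fall within the usual scatter, with no clear direction. Compound 4 is therefore estimated at 22%, within a range from 8% to 38%.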

Compound 4, a percentage reported as inhibition, at one concentration (the size of the read-out at that concentration, not a potency): 58.5%
For compound 4 the middle estimate is 36.5 percentage points below the measured one; the whole stated range lies below it.
By their numbers in this assay, from the lowest: compounds 3 and 1 (each within the scatter of the next); then compound 2; then compound 4.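

In this assay this position on the core proves highly responsive: bromo in place of hydrogen on an aromatic carbon, two atoms from the ring nitrogen, gives a number 39.6 percentage points higher from compound 1 to compound 4 (beyond the scatter) with the rest of compound 1 left unchanged. The earlier compounds shown here all carry hydrogen at this place, so they could not show that a single added heavy atom on the shared core can shift the read-out by this much. The data offer no explanation for the size of this step.

As far as these compounds go, it remains open whether bromo at this position would give a similar step with the sulfonyl partners of compound 2 and compound 3. From the compounds shown here alone, it is also open whether another group here, such as chloro, methyl or an amine, would behave as bromo does.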